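Benzyl for Cyclohexyl on the Ring Nitrogen

The compounds below may be only part of what the source reports. "The series", "measured", "known", "first", "only" and "open" are said of these compounds alone.

In a functional assay on OVCAR-4 cells (Homo sapiens) for inhibition, read by sulforhodamine B assay, with a stated time of 48 h, tested at 10 uM (on this read-out lower numbers stand for less inhibition and higher numbers for more inhibition at the one concentration tested (going by the name of the read-out)), compound 2 `c1ccc2c(-c3cn4ccnc4c(-c4ccc5ncn(C6CCCCC6)c5c4)n3)cccc2c1` gives 19.7%, the higher of the two numbers measured. Going by the values given here, compound 1 `Brc1cn2ccnc2c(-c2ccc3ncn(C4CCCCC4)c3c2)n1` gives 9.15%, and the only measured step, a number 10.6 percentage points higher from compound 1 to compound 2 (beyond the scatter), changes a different place on the shared core. Compound 3 `c1ccc(Cn2cnc3ccc(-c4nc(-c5cccc6ccccc56)cn5ccnc45)cc32)cc1` differs from compound 2 by benzyl in place of cyclohexyl on an aromatic nitrogen. Among the compounds with values here, no measured step touches this aromatic nitrogen, so nothing in the data points in either direction, and no step beyond the scatter is expected. Compound 3 is therefore estimated at 20%, within 5% to 40%. That estimate corresponds to an expected step of a number 0.3 percentage points higher from compound 2 to compound 3 (within the scatter).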

Compound 3, a percentage reported as inhibition, at one concentration (the size of the read-out at that concentration, not a potency): 7.88%
Beside the measured number, compound 3's estimate is 12.1 percentage points above it; measured number inside the range.
By their numbers in this assay, from the lowest: compounds 3 and 1 (each within the scatter of the next); then compound 2.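

In this assay the ring nitrogen proves not to be a neutral place: benzyl in place of cyclohexyl gives a number 11.8 percentage points lower from compound 2 to compound 3 (beyond the scatter) and so moves the read-out at a position the earlier step did not touch. This change is modest and rests on a single pair, with naphthalen-1-yl held constant. No available evidence bears on this change.

As far as these compounds go, whether a methyl, a longer alkyl chain or a chain ending in an amine or a carboxylic acid on this nitrogen would raise or lower the number remains open. So does whether the same change would repeat with bromo in place of naphthalen-1-yl.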